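Replacing a Difluorophenyl by Chlorophenyl on a Chalcone Amide

This account rests on a few compounds, and the source may have more. Where it says the series, first, only, none or still open, it means among the compounds named here.

Compound 1 `CC(C)Cc1ccc(C(=O)/C=C/c2ccc(C(=O)O)cc2)cc1`, compound 2 `COC(=O)c1cc(-c2cccc(NC(=O)c3ccc(/C=C/C(=O)c4cc(F)ccc4F)cc3)c2)on1` and compound 3 `CCCOc1ccc(C(=O)/C=C/c2ccc(C(=O)O)cc2)cc1` have been measured in an ADME assay on Vero cells (Chlorocebus sabaeus) for cytotoxicity, read by MTT assay, with a stated time of 72 h; on this read-out higher numbers stand for lower toxicity in this test and lower numbers for higher toxicity in this test. Compound 1 gives < 10 ug/mL, which is a limit of the assay and not a number. Compound 3 gives < 10 ug/mL, also a limit. Compound 2 gives > 40 ug/mL, again a limit rather than a number.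

Compound 2 therefore stands at the limit of > 40 ug/mL in this assay, at which 1 of the 3 values shown sits, while the other two sit at the limit of < 10 ug/mL in this assay, at which 2 of the 3 values shown sit. Going by the values given here, the only step between measured compounds, a step that the two limits leave unreadable from compound 1 to compound 3, cannot be read because both ends are limits.

Compound 4 `COC(=O)c1cc(-c2cccc(NC(=O)c3ccc(/C=C/C(=O)c4ccc(Cl)cc4)cc3)c2)on1` differs from compound 2 in one place: 4-chlorophenyl in place of 2,5-difluorophenyl on a carbonyl carbon. The 2,5-difluorophenyl leaves and a 4-chlorophenyl enters on a carbonyl carbon whose other neighbour is a double-bonded chain carbon. Among the compounds with values here, no measured step concerns an exchange of this kind, and the one step that exists is unreadable, so nothing in the data points toward a change in either direction. The step that the limit leaves unreadable from compound 2 to compound 4 is expected to be none beyond the scatter. Compound 4 is accordingly estimated at 50 ug/mL, with a range from 20 ug/mL to 120 ug/mL, most likely reported again as a limit.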

Compound 4, half-maximal cytotoxic concentration: > 50 ug/mL
Compound 4 ended at the assay's limit; the forecaster's own chance of this, stated with the estimate: 70%; the middle value lies on the limit itself.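

Going by these compounds alone, compound 2 and compound 4 both ended at limits of this assay and not at numbers, so the exchange of 2,5-difluorophenyl for 4-chlorophenyl yields no step that can be read. The compounds shown leave open how far either true value lies past its limit, and whether this exchange alters toxicity in this test at all.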